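Methyl-for-hydrogen step at the ring amine, compound 4

The compounds below may be only part of what the source reports. "The series", "measured", "known", "first", "only" and "open" are said of these compounds alone.

Compound 1 `COc1cc(/C=C2\CN(C)C/C(=C\c3cc(OC)c(OC)c(OC)c3)C2=O)cc(OC)c1OC` and compound 2 `CCN1C/C(=C\c2cc(OC)c(OC)c(OC)c2)C(=O)/C(=C/c2cc(OC)c(OC)c(OC)c2)C1` share one core and differ by methyl in place of hydrogen on a saturated chain carbon bound to an amine nitrogen in a ring. In a functional assay on NCI-H460 cells (Homo sapiens) for cytotoxicity, read by MTT assay, with a stated time of 72 h (a higher number here means a weaker inhibitor, a lower number a stronger inhibitor), compound 1 gives 1000 nM, and compound 2 gives 4900 nM, so the step of a 4.9-fold higher number from compound 1 to compound 2 (0.69 log units; beyond the scatter) goes toward weaker inhibition. Compound 3 `COc1ccc(/C=C2\CN(C)C/C(=C\c3ccc(OC)c(OC)c3)C2=O)cc1OC` carries a different core; the difference between the two cores is not broken down here. In this assay compound 3 gives 3100 nM, a higher number than compound 1 and within the scatter of compound 2. Compound 4 `CCN1C/C(=C\c2ccc(OC)c(OC)c2)C(=O)/C(=C/c2ccc(OC)c(OC)c2)C1` repeats the change on compound 3: methyl in place of hydrogen on a saturated chain carbon bound to an amine nitrogen in a ring, at the same place word for word. Among the compounds shown the change occurs twice, once with a measured outcome. Among the compounds with values here, the only precedent is the step of a 4.9-fold higher number from compound 1 to compound 2 (0.69 log units; beyond the scatter), and the expectation for compound 4 rests on it, tempered by the different core, so a step in the same direction and of broadly similar size is expected, a 4.5-fold higher number from compound 3 to compound 4 (0.65 log units; beyond the scatter). Compound 4 is accordingly estimated at 14000 nM in this assay, with a range from 5500 nM to 35000 nM.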

Compound 4, half-maximal inhibitory concentration: 3600 nM
For compound 4 the middle estimate is 3.9-fold (0.59 log units) above the measured one, outside the stated range (below it).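

In this assay the change of methyl to ethyl at the ring amine does not carry over from one core to the other at the same size: the same change on two cores in this assay, a 4.9-fold higher number (0.69 log units; beyond the scatter) from compound 1 to compound 2 and a 1.2-fold higher number (0.06 log units; within the scatter) from compound 3 to compound 4, 4.2-fold (0.63 log units) apart, beyond the scatter of two such steps. On the core of compound 3 the step is a 1.2-fold higher number from compound 3 to compound 4 (0.06 log units; within the scatter), so no shift can be read there, whereas the core of compound 1 gives a step toward weaker inhibition, a 4.9-fold higher number from compound 1 to compound 2 (0.69 log units; beyond the scatter). This shows that, within these two pairs, the step on one core is a poor guide to the step on the other, but it does not show which feature of the cores sets the gap, and two pairs give no rule for any further core.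

The compounds shown hold only methyl and ethyl on the amine nitrogen in the ring, which leaves open how a propyl chain or a benzyl group there would read on either core. Also open, going by these compounds, is whether the gap between the two steps would recur on another core.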